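Shortening the amine side chain on the shared core

The source may hold more compounds than are shown below. What is called first, only, known or untested is meant among the compounds shown, and "the series" means these compounds.

Compound 1 `C[C@@H](Nc1c(C(=O)NCc2ccc(F)cc2)nc(Br)c2cccnc12)c1ccccc1`: in a functional assay on HCT-116 cells (Homo sapiens) for cytotoxicity, read by MTT assay, with a stated time of 72 h (a higher number here means a weaker inhibitor, a lower number a stronger inhibitor), compound 1 gives > 20000 nM, which is a limit of the assay.
Compound 2 `CNCCCNc1c(C(=O)NCc2ccc(F)cc2)nc(Br)c2cccnc12`: in this assay compound 2 gives 9000 nM.
Compound 3 `CN(C)CCCNc1c(C(=O)NCc2ccc(F)cc2)nc(Br)c2cccnc12`: in this assay compound 3 gives > 10000 nM, again a limit of the assay.

Compound 3 therefore stands only at a limit, as does compound 1; two of the three values shown are limits (the limit of > 10000 nM in this assay, at which 1 of the 3 values shown sits, (the limit of > 20000 nM in this assay, at which 1 of the 3 values shown sits)), and only compound 2 has a number. The next step goes to compound 4 `CNc1c(C(=O)NCc2ccc(F)cc2)nc(Br)c2cccnc12`, with the change (hydrogen in place of 2-(dimethylamino)ethyl on a saturated chain carbon bound to a nitrogen on an aromatic ring).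

Of the measured steps, the change on the nitrogen on the aromatic ring from compound 1 to compound 2 gave an at least 2.2-fold lower number from compound 1 to compound 2 (0.34 log units; beyond the scatter), while a step that the two limits leave unreadable from compound 1 to compound 3 and the methylation step an at least 1.1-fold higher number from compound 2 to compound 3 (0.04 log units; that floor lies within the scatter). None of these removes the chain altogether, and all three compounds sit at or near the top of the range in this assay, so the bearing on the step to compound 4 is loose.

The expectation for compound 4 is a step that the limit leaves unreadable from compound 3 to compound 4, nothing beyond the scatter. Compound 4 is estimated at 15000 nM, in the range 5000 nM to 50000 nM, most probably reported only as a limit.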

Compound 4, half-maximal inhibitory concentration: > 20000 nM
Compound 4: only a limit was reported; the forecaster's own chance of this, stated with the estimate: 70%; middle value at least 1.3-fold (0.12 log units) from the limit.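

Notes on the step to compound 4: in this assay compound 4 gives > 20000 nM, a limit of the assay and the same limit as compound 1: the limit of > 20000 nM in this assay, at which 2 of the 4 values shown sit.

Cutting the chain back to methyl on the nitrogen on the aromatic ring gives an at least 2.2-fold higher number from compound 2 to compound 4 (0.34 log units; beyond the scatter) and so shows that the 3-(methylamino)propyl chain of compound 2 is not dispensable for its measured value in this series. The chain alone does not secure a number, though, and compound 3 goes against any such reading, since it keeps a chain of the same length and still stands at a limit. The steps to compound 4 from compound 3 and from compound 1 cannot be read, as limits stand at both ends of each.

Still open, from the compounds shown here alone, is how chain length and the terminal amine each contribute, for example whether a 2-(methylamino)ethyl chain, a 4-(methylamino)butyl chain or a 3-aminopropyl chain on the same nitrogen would move the value from that of compound 2. Also open, going by these compounds, is whether any change at this position gives a result well away from the top of the range, given that only compound 2 has a number.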